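Aromatic amine swap on a fused bis-thiazole series

A few compounds are considered here, and "the series" means these few. Any claim that something is new, unique, unknown or untested is made for them only; others in the source may bear on it.

Measured so far:
compound 1 `COc1ccc(Cl)cc1Nc1nc2c(s1)CCCCc1nc(NC(=O)C(C)(C)C)sc1-2` — 4100 nM
compound 2 `CCC(C)C(=O)Nc1nc2c(s1)-c1nc(Nc3cc(Cl)ccc3OC)sc1CCCC2` — 2900 nM
compound 3 `Cc1cccnc1Nc1nc2c(s1)CCCCc1nc(NC(=O)C(C)(C)C)sc1-2` — 5200 nM

All three share one core and vary at the amide and at the aromatic amine. In an assay on cells (Epithelial cell) with Cystic fibrosis transmembrane conductance regulator variant F508del (Homo sapiens) as the target, read by fluorescence, with a stated time of 20 h (a higher number here means a weaker inhibitor, a lower number a stronger inhibitor), compound 3 gives the highest of the three numbers, yet every step to it lies within the scatter: a 1.3-fold higher number from compound 1 to compound 3 (0.10 log units; within the scatter), and compound 2 gives 2900 nM against compound 3 at 5200 nM, a gap also within the scatter. Nothing in the set therefore separates these compounds.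

Compound 4 `COc1ccc([N+](=O)[O-])cc1Nc1nc2c(s1)CCCCc1nc(NC(=O)C(C)(C)C)sc1-2` differs from compound 3 by 2-methoxy-5-nitrophenyl in place of 3-methylpyridin-2-yl on a nitrogen on an aromatic ring. The step that bears on it is the earlier amine exchange, a 1.3-fold higher number from compound 1 to compound 3 (0.10 log units; within the scatter), which stayed within the scatter; the amide exchange, a 1.4-fold lower number from compound 1 to compound 2 (0.15 log units; within the scatter), did likewise. Among the compounds with values here, no measured pair covers a nitro group, so the expectation rests on the amine exchange alone. The expected step is a 1.3-fold lower number from compound 3 to compound 4 (0.11 log units; within the scatter), no change beyond the scatter. Compound 4 is estimated at 4000 nM, with a range from 1500 nM to 11000 nM.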

Compound 4, half-maximal inhibitory concentration: 900 nM
Compound 4: the middle estimate sits 4.4-fold (0.65 log units) above what was measured; the whole stated range lies above it.
By their numbers in this assay, from the lowest: compound 4; then compounds 2, 1 and 3 (each within the scatter of the next).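

The aromatic amine position can shift the number in this assay beyond the scatter (a 5.8-fold lower number from compound 3 to compound 4 (0.76 log units; beyond the scatter)), which the earlier exchange at this place did not show. Within the data shown here, the cleaner comparison is the single exchange of nitro in place of chloro on an aromatic carbon (a 4.6-fold lower number from compound 1 to compound 4 (0.66 log units; beyond the scatter)), with the methoxy and the tert-butyl amide kept the same, which ties the step to that one group rather than to the whole 2-methoxy-5-nitrophenyl. Nothing in the available data accounts for this step.

As far as these compounds go, whether nitro gives a similar step alongside the sec-butyl amide of compound 2 remains open. Also open, from the compounds shown here alone, is whether nitrile, trifluoromethyl or a carboxylic acid in the place of nitro would give a step of similar size, or whether the step is particular to nitro.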